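A few compounds are considered here, and "the series" means these few. Any claim that something is new, unique, unknown or untested is made for them only; others in the source may bear on it.

Measured in an ADME assay on L1210/0 cells (Mus musculus) for cytotoxicity, with a stated time of 48 h; on this read-out lower numbers stand for stronger inhibition and higher numbers for weaker inhibition:
compound 1 `O=c1[nH]c(=O)n([C@H]2C[C@H](O)[C@@H](CO)O2)cc1/C=N/O`: 15500 nM
compound 2 `O=c1[nH]c(=O)n([C@H]2C[C@H](O)[C@@H](CO)O2)cc1[N+](=O)[O-]`: 130 nM
compound 3 `C=C(Cl)c1cn([C@H]2C[C@H](O)[C@@H](CO)O2)c(=O)[nH]c1=O`: 1660 nM

Compound 3 sits between the other two, with a 9.3-fold lower number from compound 1 to compound 3 (0.97 log units; beyond the scatter) on one side and a 13-fold higher number from compound 2 to compound 3 (1.11 log units; beyond the scatter) on the other. Compound 4 `[N-]=[N+]=NCc1cn([C@H]2C[C@H](O)[C@@H](CO)O2)c(=O)[nH]c1=O` carries azidomethyl in place of 1-chloroethenyl on an aromatic carbon. Among the measured compounds shown here, no measured compound holds azidomethyl, so no step speaks to this group directly. The three measured steps all exchange the group at this same place, and all lie beyond the scatter, the largest being a 120-fold lower number from compound 1 to compound 2 (2.08 log units; beyond the scatter). They show that such an exchange can move the number far, but they give no direction for this one in this assay. The central expectation is therefore a step no larger than the scatter, and the estimated change is a 1.2-fold higher number from compound 3 to compound 4 (0.08 log units; within the scatter). The expected value for compound 4 is 2000 nM, with an estimated range from 250 nM to 12000 nM.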

Compound 4, half-maximal inhibitory concentration: 124000 nM
The estimate for compound 4 lay 62-fold (1.79 log units) below the measured number, outside the stated range (above it).
By their numbers in this assay, from the lowest: compound 2; then compound 3; then compound 1; then compound 4.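

In this assay this position proves to span a wider range than the earlier compounds showed: the change to azidomethyl gives a 75-fold higher number from compound 3 to compound 4 (1.87 log units; beyond the scatter), and the exchange of nitro for the same group gives a 950-fold higher number from compound 2 to compound 4 (2.98 log units; beyond the scatter), the largest step among these compounds. Compound 1 no longer holds the highest number, with an 8.0-fold higher number from compound 1 to compound 4 (0.90 log units; beyond the scatter). Groups with no ring and few heavy atoms at this aromatic carbon therefore need not give similar numbers, even where the exchange is as small as 1-chloroethenyl to azidomethyl.

No measurement at hand accounts for the size of this step. From the compounds shown here alone, whether an aminomethyl group or a longer chain ending in an azide at this place would fall nearer compound 2 or compound 4 remains open.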